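A few compounds are considered here, and "the series" means these few. Any claim that something is new, unique, unknown or untested is made for them only; others in the source may bear on it.

Compound 1 `O=c1cc(CSc2nc3ccccc3s2)oc2ccccc12`: in a functional assay on HeLa cells (Homo sapiens) for cytotoxicity, read by MTT assay, with a stated time of 72 h (on this read-out lower numbers stand for stronger inhibition and higher numbers for weaker inhibition), compound 1 gives > 25000 nM, which is a limit of the assay and not a number.
Compound 2 `Cc1cc(C)n2nc(SCc3nnc(SCc4cc(=O)c5ccccc5o4)o3)nc2n1`: compound 2 gives > 25000 nM, again a limit of the assay.
Compound 3 `Cc1cc(C)n2nc(SCc3nnc(SCc4coc5ccccc5c4=O)n3N)nc2n1`: compound 3 gives > 25000 nM, also a limit of the assay.

Compound 1 therefore stands nowhere in particular on a scale: its value is only a limit, and the same holds for the other two compounds, since (the limit of > 25000 nM in this assay, at which 3 of the 3 values shown sit). Within the data shown here, no pair among the measured compounds differs in a single place, so no measured step is available.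

Compound 4 `O=c1cc(CSc2nc3ccccc3s2)oc2ccc(Cl)cc12` differs from compound 1 by chloro in place of hydrogen on an aromatic carbon. Among the measured compounds shown here, with no measured step to lean on, the expected change in this assay from compound 1 to compound 4 is none beyond the scatter: the most likely outcome is that the assay again reports only a limit. Compound 4 is accordingly estimated at 30000 nM, with a range from 8000 nM to 100000 nM, a step from compound 1 of a step that the limit leaves unreadable from compound 1 to compound 4, most probably ending as another limit.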

Compound 4, half-maximal inhibitory concentration: > 25000 nM
Compound 4: no number, only a limit; the forecaster's own chance of this, stated with the estimate: 80%; the middle value is on the limit's open side.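

In this assay compound 4 gives > 25000 nM, a limit of the assay and not a number. Among these compounds, compound 1 gives > 25000 nM, also a limit, so no step between compound 1 and compound 4 can be read. The compounds shown leave open what chloro in place of hydrogen does to the read-out, because every value is a limit: the limit of > 25000 nM in this assay, at which 4 of the 4 values shown sit.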